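A Larger Amino Group on Compound 2

The source may report more compounds than this note shows. Statements on the series, on what has been measured and on what is new or still open speak of the compounds shown alone.

Measured in a functional assay on Hep 3B2 cells (Homo sapiens) for antiproliferative activity; on this read-out lower numbers stand for stronger inhibition and higher numbers for weaker inhibition:
- compound 1 `CCn1cc(-c2nnc(SCc3nnc(-c4ccc(F)cc4)o3)[nH]2)c(=O)c2cc(F)c(N3CCN(C)CC3)cc21`: 3800 nM
- compound 2 `CCn1cc(-c2nn(CN(C)C)c(=S)o2)c(=O)c2cc(F)c(N3CCN(C)CC3)cc21`: 8400 nM
- compound 3 `CCn1cc(-c2nnc(SCc3nnc(-c4ccccc4OC)o3)[nH]2)c(=O)c2cc(F)c(N3CCN(C)CC3)cc21`: 3800 nM

Compound 2 gives 8400 nM, the highest of the three numbers and so the weakest inhibition here. Its gap to each of the other two compounds lies beyond the usual scatter, though only just.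

Compound 4 `CCn1cc(-c2nn(CNc3ccc(Cl)cc3)c(=S)o2)c(=O)c2cc(F)c(N3CCN(C)CC3)cc21` has (4-chlorophenyl)amino in place of dimethylamino on a saturated chain carbon bound to an aromatic nitrogen. Among the measured compounds shown here, no measured step touches this place. For the measured compounds named here, the only step available is no change at the digits printed from compound 1 to compound 3 (within the scatter), which swaps 2-methoxyphenyl for 4-fluorophenyl elsewhere in the molecule. It therefore says little, beyond showing one aromatic change that left the number in place.

Indirect support comes from the values themselves. Compound 1 carries a 4-fluorophenyl and reads 3800 nM, and compound 3 carries a 2-methoxyphenyl and reads 3800 nM. However, both differ from compound 2 in much more than that ring, so this is a weak guide. A modest move toward stronger inhibition in this assay is expected, with real uncertainty about its size and even its direction. The estimated step is a 1.9-fold lower number from compound 2 to compound 4 (0.27 log units; within the scatter). The estimate for compound 4 is 4500 nM, with an expected range from 1500 nM to 12000 nM.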

Compound 4, half-maximal inhibitory concentration: 45400 nM
Beside the measured number, compound 4's estimate is 10-fold (1.00 log units) below it, outside the stated range (above it).
By their numbers in this assay, from the lowest: compounds 1 and 3 (each within the scatter of the next); then compound 2; then compound 4.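

In this assay, putting (4-chlorophenyl)amino in place of dimethylamino on a saturated chain carbon bound to an aromatic nitrogen gives a 5.4-fold higher number from compound 2 to compound 4 (0.73 log units; beyond the scatter) and thus moves toward weaker inhibition. Among the compounds shown here, this is the first measured step at this place, and it shows that the number responds to the group held there, whereas the only earlier step, no change at the digits printed from compound 1 to compound 3 (within the scatter) (a change elsewhere in the molecule), showed nothing about this position. Nothing measured here gives a reason for the rise.

The change brings in a six-membered aromatic ring, a chlorine and a hydrogen-bond donor all at once, so the compounds shown cannot tell which of these parts goes with the higher number. Going by these compounds, whether a phenylamino group without the chlorine, or a cyclic amine such as morpholine, would read closer to compound 2 or closer to compound 4 stays open, as does whether any group at this place could give a lower number than dimethylamino does.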